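The compounds below may be only part of what the source reports. "The series", "measured", "known", "first", "only" and "open" are said of these compounds alone.

Measured so far in a functional assay on RAW264.7 cells (Mus musculus) for inhibition, read by microscopy, with a stated time of 4 days, in the presence of a further agent that is not named here; on this read-out higher numbers stand for weaker inhibition and lower numbers for stronger inhibition:
- compound 1, `O=C(Nc1ccc(I)cc1F)c1cc(F)ccc1O`: 1570 nM
- compound 2, `O=c1oc2ccc(Cl)cc2c(=O)n1-c1ccc(I)cc1F`: 2050 nM

Compound 1 holds the lower of the two half-maximal inhibitory concentrations, but compound 2 sits within the usual scatter of it, so no order between the two can be read from these numbers. Among the measured compounds shown here, no pair of measured compounds differs in only one place, so no single-change step has been seen in this assay yet.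

Compound 3, `O=C(Nc1ccc(Br)cc1F)c1cc(F)ccc1O`, is the next one to be measured. Its change from compound 1: bromo in place of iodo on an aromatic carbon. For the measured compounds named here, exchanging one halogen for another of the same kind of group at the same place is a small alteration, and with no measured step to draw on, the expectation for this assay is a change no larger than the scatter, in either direction. Because compound 1 gives 1570 nM in this assay, compound 3 is expected to give 1900 nM, with a range of 800 nM to 4500 nM. That estimate means a step of a 1.2-fold higher number from compound 1 to compound 3 (0.08 log units; within the scatter).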

Compound 3, half-maximal inhibitory concentration: 1860 nM
Compound 3: the middle estimate sits 1.0-fold (0.01 log units) above what was measured, and the stated range covers the measured number.
By their numbers in this assay, from the lowest: compounds 1, 3 and 2 (each within the scatter of the next).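

In this assay, bromo in place of iodo on an aromatic carbon, para to a large group, gives a 1.2-fold higher number from compound 1 to compound 3 (0.07 log units; within the scatter), so at this position the exchange of one halogen for the other leaves a difference that cannot be told from the scatter. Among the compounds shown here, this is the first single-change step, and it gives a first reading of this position that compounds 1 and 2 could not provide. No measurement here bears on why the two halogens read alike.

On these data alone, whether an amine, a nitrile or a carboxylic acid at this position would shift the number beyond the scatter remains open. Also open, as far as these compounds go, are the part played by the fluoro group on the same ring and whether the same halogen exchange would read alike on the core of compound 2.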